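Swapping Fluoro for Methyl on the Benzyl Ring

The source may hold more compounds than are shown below. What is called first, only, known or untested is meant among the compounds shown, and "the series" means these compounds.

The compounds measured so far, all in a functional assay on B16-F10 cells (Mus musculus) for inhibition, read by MTT assay, with a stated time of 72 h; a lower number here means a stronger inhibitor, a higher number a weaker inhibitor:
compound 1, `N#Cc1c(Nc2ccc(Cl)cc2)nc(SCc2cn(Cc3ccccc3Cl)nn2)nc1-c1ccccc1`, gives 1590 nM
compound 2, `Cc1ccc(Nc2nc(SCc3cn(Cc4ccc(Cl)cc4)nn3)nc(-c3ccccc3)c2C#N)cc1`, gives 15100 nM
compound 3, `Cc1ccc(Nc2nc(SCc3cn(Cc4ccc(F)cc4)nn3)nc(-c3ccccc3)c2C#N)cc1`, gives 3040 nM

Compound 3 stands second highest of these three numbers. Its nearest neighbour is compound 1, whose number is lower by a gap that lies within the usual scatter, so the two cannot be told apart. Compound 2 is furthest away, and the step of a 5.0-fold lower number from compound 2 to compound 3 (0.70 log units; beyond the scatter) lies beyond the scatter.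

Compound 4, `Cc1ccc(Cn2cc(CSc3nc(Nc4ccc(C)cc4)c(C#N)c(-c4ccccc4)n3)nn2)cc1`, has not yet been measured. It differs from compound 3 in a single place: methyl in place of fluoro on an aromatic carbon. Among the compounds with values here, only one measured step touches this position, the exchange of chloro for fluoro from compound 2 to compound 3, and it was a clear change. Within the data shown here, no measured compound carries a methyl at this spot, so there is no direct guide. Given that a chloro there gave a markedly higher number than a fluoro, a rise from compound 3 is expected, though a smaller one than the chloro step, with wide uncertainty. For compound 4 the expected value in this assay is 6000 nM, in the range 2000 nM to 20000 nM. That estimate corresponds to an expected step of a 2.0-fold higher number from compound 3 to compound 4 (0.30 log units; within the scatter).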

Compound 4, half-maximal inhibitory concentration: 8160 nM
For compound 4 the middle estimate is 1.4-fold (0.13 log units) below the measured one, and the stated range covers the measured number.
By their numbers in this assay, from the lowest: compounds 1 and 3 (each within the scatter of the next); then compounds 4 and 2 (each within the scatter of the next).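

In this assay, putting methyl in place of fluoro on the benzyl ring gives a 2.7-fold higher number from compound 3 to compound 4 (0.43 log units; beyond the scatter) and so the fluoro compound now stands apart from two different groups at this spot, not from chloro alone. The methyl and chloro compounds cannot be told apart, with a 1.9-fold lower number from compound 2 to compound 4 (0.27 log units; within the scatter) as their step, so among these three groups only fluoro gives the lower number, while chloro and methyl read as a single level. Nothing available beyond the numbers themselves explains why fluoro differs from the other two.

Going by these compounds, three groups make only a short series, so it remains open whether a hydrogen, a methoxy group, an amine or a carboxylic acid at this place would fall with fluoro or with chloro and methyl. Also open is whether the gap between the 4-fluorobenzyl and 4-methylbenzyl compounds would hold if the rest of the molecule changed, for instance with the 4-chlorophenyl group that compound 1 carries in place of the 4-methylphenyl group of these compounds.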